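The source may report more compounds than this note shows. Statements on the series, on what has been measured and on what is new or still open speak of the compounds shown alone.

Working notes on the series. Compound 1 `CC1=CC[C@H](C(C)(C)NC(=S)N/N=C/c2ccc(O)cc2)CC1` in a functional assay on HT-29 cells (Homo sapiens) for inhibition, read by sulforhodamine B assay, with a stated time of 48 h (a lower number here means a stronger inhibitor of growth, a higher number a weaker inhibitor of growth), gives > 100000 nM, which is a limit of the assay and not a number. Compound 2 `CC1=CC[C@H](C(C)(C)NC(=S)N/N=C/c2ccc(N(C)C)cc2)CC1` in this assay gives > 100000 nM, again a limit. The step that the two limits leave unreadable from compound 1 to compound 2 therefore cannot be read, since both values sit at the limit of > 100000 nM in this assay, at which 2 of the 2 values shown sit. Compound 1 thus stands only at the limit, with no number to place it against.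

Compound 3 `CC1=CC[C@H](C(C)(C)NC(=S)N/N=C/c2ccc[nH]2)CC1` differs from compound 1 by 1H-pyrrol-2-yl in place of 4-hydroxyphenyl on a carbon with a double bond to nitrogen. Among the compounds with values here, no measured step bears on this exchange: the single step replaces one group on the aromatic ring by another and is itself unreadable. With compound 1 at a limit, the expected step is a number no higher from compound 1 to compound 3 (the limit leaves the size open), with no direction beyond the scatter to be claimed. Compound 3 is therefore expected to give about 100000 nM in this assay, within 30000 nM to 300000 nM, most likely reported as a limit again.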

Compound 3, concentration for total growth inhibition: > 100000 nM
Compound 3 ended at the assay's limit; the forecaster's own chance of this, stated with the estimate: 80%; the middle value sits exactly at the limit.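

In this assay compound 3 gives > 100000 nM as a limit and not a number, so the step from compound 1 to compound 3 cannot be read: the limit of > 100000 nM in this assay, at which 3 of the 3 values shown sit. The compounds shown leave open whether any group at this place on the shared core gives a readable value in this assay and how the three compounds compare.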